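The source may report more compounds than this note shows. Statements on the series, on what has been measured and on what is new or still open speak of the compounds shown alone.

Two compounds of the series have numbers in an assay on isolated protein for displacement of a labelled ligand from metabotropic glutamate receptor 5 (Homo sapiens), with a stated time of 60 min, tested at 1 uM; on this read-out lower numbers stand for less inhibition and higher numbers for more inhibition at the one concentration tested (going by the name of the read-out). Compound 1 `CC1CCN(c2c(S(=O)(=O)c3ccccc3)cnc3ccc(Cl)cc23)CC1` gives 59%. Compound 2 `Cc1ccc2ncc(S(=O)(=O)c3ccc(C#N)cc3)c(N3CCC(C)CC3)c2c1` gives 55% in this assay; the two numbers lie within the usual scatter of repeat measurements of each other, so compound 2 and compound 1 stand together and neither is set apart from the other. Compound 3 `Cc1ccc2ncc(S(=O)(=O)c3ccccc3)c(N3CCC(C)CC3)c2c1` has not yet been measured in this assay. It differs from compound 2 in one place: hydrogen in place of cyano on an aromatic carbon. The rest of the molecule is unchanged. Among the compounds with values here, no measured pair of this kind is available, so the expectation rests on the two numbers at hand, which sit close together. The expected step is a number 1 percentage points higher from compound 2 to compound 3 (within the scatter), within the scatter and in no direction beyond it. Compound 3 is therefore estimated to give about 56% in this assay, with a range from 40% to 72%.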

Compound 3, a percentage reported as inhibition, at one concentration (the size of the read-out at that concentration, not a potency): 67%
The estimate for compound 3 lay 11 percentage points below the measured number, within the range that was stated.
By their numbers in this assay, from the lowest: compounds 2, 1 and 3 (each within the scatter of the next, the first and the last beyond it).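

In this assay, within the data shown here, the change from 4-cyanophenyl to phenyl, on the aromatic carbon para to a large group, gives a number 12 percentage points higher from compound 2 to compound 3 (beyond the scatter) and is the first single-place step to pass the scatter; with the rest of compound 2 unchanged, hydrogen at this carbon reads higher than cyano. Methyl in place of chloro on an aromatic carbon gives a number 8 percentage points higher from compound 1 to compound 3 (within the scatter) and so does not separate these two compounds. Nothing at hand bears on the cause of either step.

Only cyano and hydrogen are shown at this carbon, so it remains open how a methoxy, fluoro or carboxylic acid group there would read. Also open, going by these compounds, is whether the cyano to hydrogen step carries over to the chloro core of compound 1.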